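Sulfanyl Added to a Fused Core That Sits at Two Limits

A few compounds are considered here, and "the series" means these few. Any claim that something is new, unique, unknown or untested is made for them only; others in the source may bear on it.

Compound 1 `CNc1nc2cc(Cl)c(Cl)cc2n1COCCO`: in a functional assay on KB cells (Homo sapiens) for inhibition (on this read-out lower numbers stand for stronger inhibition and higher numbers for weaker inhibition), compound 1 gives > 100000 nM, which is a limit of the assay and not a number.
Compound 2 `OCCOCn1cnc2cc(Cl)c(Cl)cc21`: in this assay compound 2 gives > 100000 nM, again a limit of the assay.

Compound 2 therefore stands at the limit, with no number of its own. Within the data shown here, the only step measured, a step that the two limits leave unreadable from compound 1 to compound 2, cannot be read in size because both values sit at the limit of > 100000 nM in this assay, at which 2 of the 2 values shown sit. Compound 3 `OCCOCn1c(S)nc2cc(Cl)c(Cl)cc21` differs from compound 2 by sulfanyl in place of hydrogen on an aromatic carbon. Among the measured compounds shown here, no measured step in this assay bears on that change, so no direction and no size can be drawn from it. For compound 3 a limit is expected again rather than a number, and the estimate is 100000 nM, between 30000 nM and 300000 nM. The expected step of a number no higher from compound 2 to compound 3 (the limit leaves the size open) is thus none beyond the scatter.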

Compound 3, half-maximal inhibitory concentration: > 100000 nM
Compound 3: only a limit was reported (the forecaster's own chance of this, stated with the estimate: 80%); the middle value lies on the limit itself.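

Among these compounds, compound 3 also sits at a limit of the assay, so no step among compound 1, compound 2 and compound 3 can be read: the limit of > 100000 nM in this assay, at which 3 of the 3 values shown sit. The compounds shown leave open whether methylamino, hydrogen and sulfanyl on this aromatic carbon differ at all in this assay.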